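The source may hold more compounds than are shown below. What is called first, only, known or untested is meant among the compounds shown, and "the series" means these compounds.

Measured compounds:
compound 1 `C=C(C)[C@H]1CC=C(C)[C@@]2(O)[C@@H]1[C@H](c1ccccc1Br)O[C@@H]2C(=O)OC`, 5000 nM
compound 2 `C=C(C)[C@H]1CC=C(C)[C@@]2(O)[C@@H]1[C@H](c1cccc(Cl)c1Cl)O[C@@H]2C(=O)OCC`, 5000 nM
compound 3 `C=C(C)[C@H]1CC(=O)C(C)=C2[C@@H](C(=O)OCC)O[C@@H](c3cccc(Br)c3)[C@@H]21`, 30000 nM

In a functional assay on KB3 cells (Homo sapiens) for antiproliferative activity, read by MTT assay, with a stated time of 96 h (on this read-out lower numbers stand for stronger inhibition and higher numbers for weaker inhibition), compound 1 gives 5000 nM, level with compound 2 at the digits shown and within the scatter; together these are the two lowest numbers of the three. Compound 3 sits furthest off with 30000 nM, a gap beyond the scatter. Compound 4 `C=C(C)[C@H]1CC=C(C)[C@@]2(O)[C@@H]1[C@H](c1ccccc1Br)O[C@@H]2C(=O)OCC1CCCC1` is not yet measured. It differs from compound 1 by cyclopentyl in place of hydrogen on a saturated chain carbon bound to an oxygen next to a carbonyl group. Going by the values given here, no step between measured compounds matches this change. Because compound 2 gives 5000 nM, level with compound 1, a change at the ester is expected to produce no shift beyond the scatter in this assay. The step of a 1.3-fold lower number from compound 1 to compound 4 (0.10 log units; within the scatter) is therefore expected to be small. Compound 4 is estimated at 4000 nM, within 1500 nM to 12000 nM.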

Compound 4, half-maximal inhibitory concentration: > 100000 nM
Compound 4 gave a limit, no number; the forecaster's own chance of this, stated with the estimate: 5%; middle value at least 25-fold (1.39 log units) away from the limit.
By their numbers in this assay, from the lowest: compounds 1 and 2 (each within the scatter of the next); then compound 3. At a limit, above all of these: compound 4.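

In this assay, the ester of compound 1 tolerates poorly the cyclopentyl in place of hydrogen, with an at least 20-fold higher number from compound 1 to compound 4 (1.30 log units; beyond the scatter). Compound 4 carries a limit of the assay, not a number: the limit of > 100000 nM in this assay, at which 1 of the 4 values shown sits.

Going by these compounds alone, the earlier compounds differ from one another in more than one place, so this is the first change at the ester that can be read on its own.

Open, on these data alone, is how much smaller a group, such as ethyl or cyclopropylmethyl, would already shift the value on this core. As far as these compounds go, a carboxylic acid or an amide in place of the ester also remains open.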